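The compounds below may be only part of what the source reports. "The series", "measured", "known", "first", "only" and "open" are said of these compounds alone.

Measured compounds in a functional assay on T47D cells (Homo sapiens) for cytotoxicity, read by CCK-8 assay and cell counting, with a stated time of 2 days; on this read-out lower numbers stand for stronger inhibition and higher numbers for weaker inhibition:
compound 1 `Oc1ccc(-c2cc(-c3cccc(Cl)c3)nc(-c3ccccn3)c2)cc1`: 27900 nM
compound 2 `Oc1cccc(-c2cc(-c3cccc(Cl)c3)nc(-c3ccccn3)c2)c1`: "not determined" (no result reported)
compound 3 `Oc1cccc(-c2cc(-c3ccsc3)nc(-c3ccccc3Cl)c2)c1`: 2440 nM

Compound 1 stands highest of the two numbers on record; the nearest, compound 3, gives 2440 nM, a gap beyond the usual scatter. Compound 2 gives "not determined" (no result reported), so it carries no number. Going by the values given here, no pair of measured compounds differs in a single place, so no measured step exists to guide the next one.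

Compound 4 `Oc1ccc(-c2cc(-c3cccnc3)nc(-c3cccc(Cl)c3)c2)cc1` differs from compound 1 as follows: pyridin-3-yl in place of pyridin-2-yl on an aromatic carbon. Among the compounds with values here, with no measured step of this kind to lean on, the step of a 1.1-fold lower number from compound 1 to compound 4 (0.05 log units; within the scatter) is expected to remain within the scatter, in no clear direction. Compound 4 is therefore estimated at 25000 nM, with a range from 8000 nM to 80000 nM.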

Compound 4, half-maximal inhibitory concentration: 25700 nM
Compound 4: the middle estimate sits 1.0-fold (0.01 log units) below what was measured, and the stated range covers the measured number.
By their numbers in this assay, from the lowest: compound 3; then compounds 4 and 1 (each within the scatter of the next).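

In this assay, going by these compounds alone, pyridin-3-yl in place of pyridin-2-yl gives the first single-place step (a 1.1-fold lower number from compound 1 to compound 4 (0.04 log units; within the scatter)), and it lies within the scatter. On an aromatic carbon next to the ring nitrogen of the core, these two pyridinyl groups therefore cannot be told apart on this read-out. Nothing available explains this result.

From the compounds shown here alone, it remains open whether an amine or a carboxylic acid at this position would move the number beyond the scatter. Going by these compounds, it is also open whether this pyridinyl swap would give the same result with another group in place of the 3-chlorophenyl group.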